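Swapping bromo for hydrogen on compound 1

This account rests on a few compounds, and the source may have more. Where it says the series, first, only, none or still open, it means among the compounds named here.

Two compounds have been measured so far in a physicochemical assay for lipophilicity, measured as octanol-water partition (a lower number here means a more polar compound, a higher number a more lipophilic compound), and read as follows:

- compound 1 `O=C(COc1cccc2ccccc12)N/N=C/c1ccccc1Br` gives 4.81
- compound 2 `C/C(=N\NC(=O)COc1cccc2ccccc12)c1ccccc1Br` gives 4.44

Compound 1 holds the higher of the two numbers, and its gap to compound 2 lies beyond the usual scatter of repeated measurements. Compound 3 `O=C(COc1cccc2ccccc12)N/N=C/c1ccccc1` has no number yet. It differs from compound 1 in a single place hydrogen in place of bromo on an aromatic carbon where hydrogen takes the place of bromo on an aromatic carbon, so that 2-bromophenyl becomes phenyl. Among the measured compounds shown here, no measured pair shows this exchange, so the expectation rests on the structural change alone. A step downward in this assay is expected, and it should lie beyond the scatter. The estimated step of a number 0.76 log units lower from compound 1 to compound 3 (beyond the scatter) is a judgement and not a measurement. Compound 3 is therefore expected at 4.05 with a likely range of 3.6 to 4.5 on this scale.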

Compound 3, partition coefficient: 4.02
Compound 3: middle estimate off by 0.03 log units, on the high side; the range from low to high includes it.
By their numbers in this assay, from the lowest: compound 3; then compound 2; then compound 1.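

Hydrogen in place of bromo on an aromatic carbon, ortho to a large group, gives the first measured single-place exchange in this set, and in this assay it amounts to a number 0.79 log units lower from compound 1 to compound 3 (beyond the scatter). The removal of one bromine atom is therefore enough on its own to shift the read-out by more than repeated measurements would, though this rests on a single pair and cannot yet be called a general rule for the series. Nothing measured here accounts for the size of this step.

On these data alone, whether an amine, a methyl or a methoxy group at the same place would read closer to compound 1 or to compound 3 remains open. Also open, as far as these compounds go, is whether bromo elsewhere on the same ring would give a step of similar size.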